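Series notes: acyl group at the aminopyrrolopyrimidine nitrogen

The compounds below may be only part of what the source reports. "The series", "measured", "known", "first", "only" and "open" are said of these compounds alone.

Measured so far in an ADME assay on HS27 cells (Homo sapiens) for antiproliferative activity, read by MTT assay, with a stated time of 24 h; a higher number here means a weaker inhibitor, a lower number a stronger inhibitor:
- compound 1, `CC(=O)Nc1ncnc2c1ccn2-c1ccc(NC(=O)Nc2ccc(Cl)c(C(F)(F)F)c2)cc1`, gives > 10000 nM, which is a limit of the assay, not a number.
- compound 2, `O=C(Nc1ccc(-n2ccc3c(NC(=O)c4ccccc4)ncnc32)cc1)Nc1ccc(Cl)c(C(F)(F)F)c1`, gives 6000 nM.
- compound 3, `O=C(Nc1ccc(-n2ccc3c(NC(=O)c4ccccc4)ncnc32)cc1)c1ccc(Cl)c(C(F)(F)F)c1`, gives 5500 nM.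

Compound 2 has the highest of the two numbers shown; its nearest neighbour is compound 3, with a 1.1-fold lower number from compound 2 to compound 3 (0.04 log units; within the scatter). Compound 1 sits at the limit described by the limit of > 10000 nM in this assay, at which 1 of the 3 values shown sits.

Compound 4, `Nc1ncnc2c1ccn2-c1ccc(NC(=O)Nc2ccc(Cl)c(C(F)(F)F)c2)cc1`, is not yet measured. It differs from compound 2 by hydrogen in place of benzoyl on a nitrogen on an aromatic ring, that is, the benzamido group of compound 2 becomes a plain amino group on the shared core.

The step that bears on this is an at least 1.6-fold lower number from compound 1 to compound 2 (0.22 log units; that floor lies within the scatter), where the acetyl of compound 1 becomes the benzoyl of compound 2; it runs from a limit to a number, so its floor is uncertain. The change to compound 4 strips the acyl group entirely, going the other way along that line. The step of a 1.1-fold lower number from compound 2 to compound 3 (0.04 log units; within the scatter) concerns the urea side and does not inform this change.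

The expectation for compound 4 is therefore a higher number than compound 2, or none beyond the scatter; the expected step is a 2.0-fold higher number from compound 2 to compound 4 (0.30 log units; within the scatter). Compound 4 is estimated at 12000 nM, within 5000 nM to 30000 nM, with a fair chance that the assay reports only a limit.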

Compound 4, half-maximal inhibitory concentration: > 10000 nM
Compound 4 gave a limit, no number (the forecaster's own chance of this, stated with the estimate: 55%); the middle value lies beyond the limit too.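

In this assay, the change from benzamido to amino gives an at least 1.6-fold higher number from compound 2 to compound 4 (0.22 log units; that floor lies within the scatter), so only a floor is known for loss of the benzoyl group, and that floor does not clear the scatter. Compound 1 and compound 4 both sit at the same limit of the assay, which is not a number: the limit of > 10000 nM in this assay, at which 2 of the 4 values shown sit. The step between these two cannot be read, so acetyl and hydrogen on this nitrogen cannot be told apart, and among the compounds shown only those carrying benzoyl there, compound 2 and compound 3, give numbers.

As far as these compounds go, how far compound 4 lies past its limit remains open. Also open, from the compounds shown here alone, is whether a longer chain such as hexanoyl, a phenylacetyl group or a benzoyl bearing a methoxy group on this nitrogen would give a number clearly apart from that of compound 2.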